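Oxadiazole to Thiadiazole: Expecting Another Limit

The source may hold more compounds than are shown below. What is called first, only, known or untested is meant among the compounds shown, and "the series" means these compounds.

Measured so far in a functional assay on HeLa cells (Homo sapiens) for cytotoxicity, read by MTT assay, with a stated time of 72 h; on this read-out lower numbers stand for stronger inhibition and higher numbers for weaker inhibition:
Compound 1 `Cc1nnc(SCc2cc(=O)c3cc(Cl)ccc3o2)o1` gives > 25000 nM, a limit of the assay and not a number.
Compound 2 `Cc1cc(C)n2nc(SCc3cc(=O)c4cc(Cl)ccc4o3)nc2n1` gives > 25000 nM, likewise a limit.
Compound 3 `Cc1nnc(SCc2cc(=O)c3ccccc3o2)o1` gives > 25000 nM, likewise a limit.

Compound 1 therefore stands nowhere in particular on a scale: its value is a limit, and every measured compound shares that situation, as the limit of > 25000 nM in this assay, at which 3 of the 3 values shown sit, states. For the measured compounds named here, the only single-point step among them, from compound 1 to compound 3, a step that the two limits leave unreadable from compound 1 to compound 3, so it tells nothing about size or direction.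

The unmeasured compound 4 `Cc1nnc(SCc2cc(=O)c3cc(Cl)ccc3o2)s1` differs from compound 1 by 5-methyl-1,3,4-thiadiazol-2-yl in place of 5-methyl-1,3,4-oxadiazol-2-yl on a sulfur. Going by the values given here, no measured step speaks to this change, and the steps that exist are unreadable because of the limit of > 25000 nM in this assay, at which 3 of the 3 values shown sit. The expectation for compound 4 is therefore that this assay again returns a limit, with an estimated step that the limit leaves unreadable from compound 1 to compound 4 from compound 1, nothing beyond the scatter. Compound 4 is estimated at 30000 nM in this assay, within a range from 10000 nM to 100000 nM.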

Compound 4, half-maximal inhibitory concentration: > 25000 nM
Compound 4 was reported as a limit; the forecaster's own chance of this, stated with the estimate: 85%; the middle value is on the limit's open side.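

In this assay compound 4 gives > 25000 nM, a limit and not a number. No size or direction can be read for the change from compound 1 to compound 4: the limit of > 25000 nM in this assay, at which 4 of the 4 values shown sit. The compounds shown leave open whether any of these structures would give a measurable value here.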